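The source may hold more compounds than are shown below. What is called first, only, known or untested is meant among the compounds shown, and "the series" means these compounds.

Compounds measured in a functional assay on HEK293 cells for agonist activity at Bile acid receptor (Homo sapiens); on this read-out lower numbers stand for smaller maximal responses and higher numbers for larger maximal responses:
compound 1 `CC(C)c1onc(-c2c(Cl)cccc2Cl)c1COc1ccc(N(C)C(=O)c2ccc(C(=O)O)cc2)c(C(F)(F)F)n1` gives 36%
compound 2 `CC(C)c1onc(-c2c(Cl)cccc2Cl)c1COc1ccc(NC(=O)c2ccc(C(=O)O)cc2)c(C(F)(F)F)n1` gives 21%

Compound 1 stands highest of the two numbers shown; its nearest neighbour is compound 2, and the one step between them, a number 15 percentage points lower from compound 1 to compound 2 (beyond the scatter), goes with hydrogen in place of methyl on an amide-type nitrogen. That step is the only one measured in this set.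

Compound 3 `Cc1nc(OCc2c(-c3c(Cl)cccc3Cl)noc2C(C)C)ccc1N(C)C(=O)c1ccc(C(=O)O)cc1` has not yet been measured. It differs from compound 1 in one place: methyl in place of trifluoromethyl on an aromatic carbon. The trifluoromethyl that leaves sits on an aromatic carbon next to the ring nitrogen, ortho to a large group and meta to a large group; the methyl that enters takes the same position.

Among the compounds with values here, no measured step bears on this change. The step from compound 1 to compound 2 concerns the amide-type nitrogen, not the aromatic carbon, so it gives no guide to the size or direction of the change to compound 3. With nothing to go on beyond the value of compound 1, the expected step of a number 3 percentage points lower from compound 1 to compound 3 (within the scatter) is none beyond the scatter, with a wide uncertainty.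

Compound 3 is therefore estimated at 33%, within a range of 12% to 58% in this assay.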

Compound 3, largest response reached (reported as efficacy), in percent of the reference or control that the assay uses: 21%
Compound 3: middle estimate off by 12 percentage points, on the high side; the measured number falls inside the stated range.
By their numbers in this assay, from the lowest: compounds 2 and 3 (each within the scatter of the next); then compound 1.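

In this assay, the result shows that the group on the aromatic carbon next to the ring nitrogen also bears on the maximal response, with methyl in place of trifluoromethyl giving a number 15 percentage points lower from compound 1 to compound 3 (beyond the scatter). Within the data shown here, until now, the only measured change lay on the amide-type nitrogen, so this is the first measured sign that a second place in compound 1 affects this read-out, with a modest step beyond the scatter. Nothing given here accounts for the lower response with methyl.

The two groups shown on this carbon leave open how a hydrogen, a chlorine, a methoxy group or an ethyl group would compare with trifluoromethyl and methyl, and so whether the response follows any simple order across such groups. From the compounds shown here alone, it is also open whether the same exchange of trifluoromethyl for methyl would give a step of similar size and direction with the amide hydrogen of compound 2 in place of the methyl on the amide-type nitrogen of compound 1.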